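The compounds below may be only part of what the source reports. "The series", "measured", "known", "first", "only" and "open" are said of these compounds alone.

Of the compounds shown here, two have been measured so far. Compound 1, `C#CCOc1ccc(Br)cc1/C=N/Cc1ccc(S(N)(=O)=O)cc1`, gives 45700 nM in a functional assay on HT-29 cells (Homo sapiens) for cytotoxicity, read by MTT assay, with a stated time of 24 h; on this read-out lower numbers stand for stronger inhibition and higher numbers for weaker inhibition. Compound 2, `NS(=O)(=O)c1ccc(C/N=C/c2ccccc2OCc2cn(CCCOc3ccc4ccc(=O)oc4c3)nn2)cc1`, gives 14300 nM in this assay. Among the compounds with values here, on these two numbers compound 2 stands lowest, with compound 1 as its only neighbour at a higher number, and that gap falls beyond the usual scatter of repeated measurements of this kind.

Compound 3, `COc1cccc(/C=N/Cc2ccc(S(N)(=O)=O)cc2)c1OCc1cn(CCCOc2ccc3ccc(=O)oc3c2)nn1`, has not been measured yet. It differs from compound 2 in a single place: methoxy in place of hydrogen on an aromatic carbon. Within the data shown here, no pair of measured compounds differs by just one change, so there is no measured step to lean on for what a methoxy group does here. Among the measured compounds shown here, compound 2 gives 14300 nM in this assay, and nothing measured so far points to a move in either direction for the change to compound 3. The step of a 1.0-fold lower number from compound 2 to compound 3 (0.01 log units; within the scatter) is therefore expected to stay within the scatter, with no direction claimed. For compound 3 the expected value in this assay is 14000 nM, with a range from 5000 nM to 40000 nM.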

Compound 3, half-maximal inhibitory concentration: 52500 nM
The estimate for compound 3 lay 3.8-fold (0.57 log units) below the measured number; the whole stated range lies below it.
By their numbers in this assay, from the lowest: compound 2; then compounds 1 and 3 (each within the scatter of the next).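

In this assay, putting methoxy in place of hydrogen on an aromatic carbon, ortho to a large group and meta to a large group, gives a 3.7-fold higher number from compound 2 to compound 3 (0.56 log units; beyond the scatter). Within the data shown here, this is the first measured step in which only one thing changes, and it shows that this carbon is not indifferent to what it carries: here, a group of 2 heavy atoms with no ring and no net charge moves the result toward weaker inhibition. Nothing measured here says why the number rises, so the step stands as an observation without an explanation.

A single step cannot show whether this loss belongs to methoxy itself or would follow from any group placed on this carbon, and a hydroxyl, a methyl or a fluorine at the same place would help to separate those two readings. On these data alone, it also remains open whether methoxy would give a similar step on another carbon of the same ring, or whether a longer chain such as ethoxy would push the number further in the same direction.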